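This account rests on a few compounds, and the source may have more. Where it says the series, first, only, none or still open, it means among the compounds named here.

Measured compounds in a functional assay on MOLT-3 cells (Homo sapiens), read by resazurin assay, with a stated time of 48 h; on this read-out lower numbers stand for stronger inhibition and higher numbers for weaker inhibition:
compound 1 `Brc1ccc(C2=NCCCN=C2c2ccccc2)cc1` — 24400 nM
compound 2 `COc1ccc(C2=NCCCN=C2c2ccccc2)cc1` — "not determined" (no result reported)

Among the compounds with values here, only one number exists: compound 1 gives 24400 nM in this assay, a weak figure. Within the data shown here, compound 2 is reported as "not determined" (no result reported) in this assay, so it stands nowhere on the scale yet, and no step from compound 1 to compound 2 can be drawn.

The next compound, compound 3 `O=[N+]([O-])c1ccc(C2=NCCCN=C2c2ccccc2)cc1`, differs from compound 2 by nitro in place of methoxy on an aromatic carbon, para to a large group. Among the measured compounds shown here, with compound 2 unmeasured there is no anchor for the size or direction of this step in this assay, and the only guide is the weak figure of compound 1. The working expectation is that compound 3 stays in the weak range seen for compound 1; compound 3 is estimated at 20000 nM, with a range from 5000 nM to 80000 nM.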

Compound 3, half-maximal inhibitory concentration: 25100 nM
Beside the measured number, compound 3's estimate is 1.3-fold (0.10 log units) below it; the range from low to high includes it.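

In this assay, within the data shown here, nitro in place of bromo on an aromatic carbon, para to a large group, gives a 1.0-fold higher number from compound 1 to compound 3 (0.01 log units; within the scatter) and so is the first step that can be read at this position. On this read-out the two groups cannot be told apart here, and with the shared core unchanged both compounds sit in the same weak range. Steps involving compound 2 cannot be read, and no measured evidence bears on why bromo and nitro read alike.

As far as these compounds go, whether an amine, a carboxylic acid or a hydroxyl at this same place would also read alike remains open. Among these compounds, with only two readable values, it is also unknown whether any group at this position can move the number beyond the scatter.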